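Replacing the sulfamoyl of compound 3 with phenyl

This account rests on a few compounds, and the source may have more. Where it says the series, first, only, none or still open, it means among the compounds named here.

Compound 1 `COC(=O)c1ccc(NC2=CC(=O)c3ncncc3C2=O)cc1` gives 1100 nM in a functional assay on PANC-1 cells (Homo sapiens) for cytotoxicity, read by MTT assay, with a stated time of 72 h; on this read-out higher numbers stand for weaker inhibition and lower numbers for stronger inhibition. Compound 2 `NC(=O)c1ccc(NC2=CC(=O)c3ncncc3C2=O)cc1` gives 6300 nM in this assay, a step of a 5.7-fold higher number from compound 1 to compound 2 (0.76 log units; beyond the scatter). Compound 3 `NS(=O)(=O)c1ccc(NC2=CC(=O)c3ncncc3C2=O)cc1` reaches only the assay limit, > 10000 nM in this assay, a limit rather than a number. Against the other two, an at least 9.0-fold higher number from compound 1 to compound 3 (0.95 log units; beyond the scatter) and an at least 1.5-fold higher number from compound 2 to compound 3 (0.20 log units; that floor lies within the scatter). Compound 4 `O=C1C(Nc2ccc(-c3ccccc3)cc2)=CC(=O)c2ncncc21` is not yet measured; its change from compound 3 is phenyl in place of sulfamoyl on an aromatic carbon. The measured steps all run toward weaker inhibition as the group on that aromatic carbon passes from methoxycarbonyl through carbamoyl to sulfamoyl; none involves phenyl, so compound 1, the strongest value, serves as the anchor. The expected step is an at least 5.0-fold lower number from compound 3 to compound 4 (0.69 log units; beyond the scatter), a return toward the level of compound 1. Compound 4 is therefore estimated at 2000 nM, within 500 nM to 8000 nM.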

Compound 4, half-maximal inhibitory concentration: 400 nM
Compound 4: the middle estimate sits 5.0-fold (0.70 log units) above what was measured; the measured number lies below the stated range.
By their numbers in this assay, from the lowest: compound 4; then compound 1; then compound 2. At a limit, above all of these: compound 3.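

In this assay, phenyl on this aromatic carbon gives the lowest number of the series, with a 2.8-fold lower number from compound 1 to compound 4 (0.44 log units; beyond the scatter) and a 16-fold lower number from compound 2 to compound 4 (1.20 log units; beyond the scatter). Phenyl has 0 hydrogen-bond donors and 0 hydrogen-bond acceptors, so neither is required in this group for the lowest number shown. The largest step rests on a limit of the assay rather than a number and gives only a floor, an at least 25-fold lower number from compound 3 to compound 4 (1.39 log units; beyond the scatter): the limit of > 10000 nM in this assay, at which 1 of the 4 values shown sits.

On these data alone, whether an aromatic ring is needed on this carbon remains open; cyclohexyl or tert-butyl would address that. As far as these compounds go, how an amine or a carboxylic acid on the phenyl would shift the number also remains open.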